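Biaryl acid series: 3-fluorophenyl to 2-hydroxyphenyl swap

The source may report more compounds than this note shows. Statements on the series, on what has been measured and on what is new or still open speak of the compounds shown alone.

Measured so far:
compound 1 `CCCCCCCCS(=O)(=O)Nc1cc(-c2cccc(F)c2)ccc1C(=O)O`: 32600 nM
compound 2 `CCCCCCCCS(=O)(=O)Nc1cc(-c2ccccc2O)ccc1C(=O)O`: 63100 nM
compound 3 `CCCCCCCCS(=O)(=O)Nc1ccc(-c2cccc(F)c2)cc1C(=O)O`: 37600 nM

All three numbers come from an assay on mitochondria (strain BALB/c) for inhibition of glycerol-3-phosphate acyltransferase 1, mitochondrial (Mus musculus), read by scintillation counting, with a stated time of 10 min; a higher number here means a weaker inhibitor, a lower number a stronger inhibitor. Compound 1 and compound 2 differ by 2-hydroxyphenyl in place of 3-fluorophenyl on an aromatic carbon; the step was a 1.9-fold higher number from compound 1 to compound 2 (0.29 log units; within the scatter). Compound 1 and compound 3 are built from the same atoms joined differently; the difference between the two cores is not broken down here, and their two values lie within the usual scatter of each other, so nothing is read from that pair.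

Compound 4 `CCCCCCCCS(=O)(=O)Nc1ccc(-c2ccccc2O)cc1C(=O)O` is not yet measured. It differs from compound 3 by 2-hydroxyphenyl in place of 3-fluorophenyl on an aromatic carbon. This is the same kind of change as that from compound 1 to compound 2, not the same change: in compound 1 the place is meta to a large group and para to a carboxy group, whereas in compound 3 it is meta to a carboxy group and para to a large group.

Going by the values given here, for compound 4 a step of a 1.9-fold higher number from compound 3 to compound 4 (0.27 log units; within the scatter) is expected in this assay, because a 1.9-fold higher number from compound 1 to compound 2 (0.29 log units; within the scatter) is the only measured instance of this kind of change. Compound 4 is therefore estimated at 70000 nM, expected between 30000 nM and 160000 nM.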

Compound 4, half-maximal inhibitory concentration: 61700 nM
For compound 4 the middle estimate is 1.1-fold (0.05 log units) above the measured one, within the range that was stated.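

In this assay, 2-hydroxyphenyl in place of 3-fluorophenyl on the core of compound 3 gives a 1.6-fold higher number from compound 3 to compound 4 (0.22 log units; within the scatter). Set beside the earlier step on the core of compound 1, the two steps do not differ: the same change on two cores in this assay, a 1.9-fold higher number (0.29 log units; within the scatter) from compound 1 to compound 2 and a 1.6-fold higher number (0.22 log units; within the scatter) from compound 3 to compound 4, 1.2-fold (0.07 log units) apart, within the scatter of two such steps. The change therefore reads the same on both cores, but each step lies within the scatter, so neither shows a real effect of the swap, and agreement on two cores sets no rule for the wider series.

The compounds shown leave open whether an amine or a methoxy group in place of the hydroxy group on the 2-hydroxyphenyl ring would give a step beyond the scatter on either core. Also open, from the compounds shown here alone, is whether a longer chain than the one shared by all four compounds would separate the two cores in this assay's read-out, which compounds 1 to 4 cannot address.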